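This account rests on a few compounds, and the source may have more. Where it says the series, first, only, none or still open, it means among the compounds named here.

Measured compounds in a functional assay on HeLa cells (Homo sapiens) for cytotoxicity, with a stated time of 72 h; on this read-out lower numbers stand for higher toxicity in this test and higher numbers for lower toxicity in this test:

compound 1, `CCCCCCCCCCN(NC(=O)COC)C(=O)OC(C)(C)C`, 104000 nM
compound 2, `CCCCCCCCCCCCCCNNC(=O)COC`, 59600 nM

Compound 2 holds the lower of the two numbers in this assay, but its gap to compound 1 lies within the scatter, so no order between them is claimed.

Compound 3, `CCCCCCCCCCNNC(=O)COC`, is not yet measured. It differs from compound 2 by hydrogen in place of butyl on a saturated chain carbon, ten or more bonds along the chain from an amine nitrogen. Without a measured step of this kind, the expectation rests on compound 1 with its value of 104000 nM, which also carries a decyl chain. The step of a 1.8-fold higher number from compound 2 to compound 3 (0.27 log units; within the scatter) is expected to be modest and upward. Compound 3 is estimated at 110000 nM, range 40000 nM to 300000 nM.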

Compound 3, half-maximal cytotoxic concentration: 138000 nM
Estimate against measurement, compound 3: 1.3-fold (0.10 log units) below, and the stated range covers the measured number.
By their numbers in this assay, from the lowest: compounds 2, 1 and 3 (each within the scatter of the next, the first and the last beyond it).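

Removing butyl, with hydrogen in its place on a saturated chain carbon, shows that this position can move the number in this assay (a 2.3-fold higher number from compound 2 to compound 3 (0.36 log units; beyond the scatter)). Hydrogen in place of tert-butoxycarbonyl on an amine nitrogen leaves no claimable change (a 1.3-fold higher number from compound 1 to compound 3 (0.12 log units; within the scatter)). Nothing available explains either step. Still open, going by these compounds, is whether a longer chain than that of compound 2 would lower the number further, and whether an amine or a carboxylic acid in place of butyl would be tolerated.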